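The compounds below may be only part of what the source reports. "The series", "measured", "known", "first", "only" and "open" are said of these compounds alone.

Measured compounds:
- compound 1, `COc1ccc(C2=Cc3ccc(F)cc3C(CC(C)=O)N2c2ccc([N+](=O)[O-])cc2)cc1`: 11200 nM
- compound 2, `COc1ccc(C2=Cc3ccc(F)cc3C(CC(=O)C(C)O)N2c2ccc(F)cc2)cc1`: 14000 nM
- compound 3, `COc1ccc(C2=Cc3ccc(F)cc3C(CC(=O)C(C)O)N2c2ccc(C#N)cc2)cc1`: 24100 nM

All three were tested in an ADME assay on TZM cells (Homo sapiens) for cytotoxicity, read by CellTiter-Glo, with a stated time of 48 h; on this read-out lower numbers stand for higher toxicity in this test and higher numbers for lower toxicity in this test. Compound 3 stands at the high end of the three numbers: compound 2 sits within the scatter of it, while compound 1 sits beyond the scatter, on the lower side. Among the compounds with values here, the one single-point step among them, a 1.7-fold higher number from compound 2 to compound 3 (0.24 log units; within the scatter), did not move the number beyond the scatter.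

Compound 4, `COc1ccc(C2=Cc3ccc(F)cc3C(CC(=O)C(C)O)N2c2ccc([N+](=O)[O-])cc2)cc1`, is the next compound, not yet measured. It differs from compound 3 in one place: nitro in place of cyano on an aromatic carbon. Within the data shown here, no measured pair shows exactly this exchange on the same core, so the nearest guide is the swap from compound 2 to compound 3, which stayed within the scatter, and the fact that compound 1, which also carries a nitro group but a different side chain, gives 11200 nM. On that basis a small downward move is expected, a 1.6-fold lower number from compound 3 to compound 4 (0.21 log units; within the scatter), still within the scatter. Compound 4 is therefore estimated at 15000 nM, with a range from 7000 nM to 32000 nM.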

Compound 4, half-maximal cytotoxic concentration: 10100 nM
Beside the measured number, compound 4's estimate is 1.5-fold (0.17 log units) above it; low and high end bracket the measured number.
By their numbers in this assay, from the lowest: compounds 4, 1, 2 and 3 (each within the scatter of the next, the first and the last beyond it).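

In this assay, the 4-cyanophenyl to 4-nitrophenyl change gives a 2.4-fold lower number from compound 3 to compound 4 (0.38 log units; beyond the scatter), the first step at this position to pass the scatter, while a 1.4-fold lower number from compound 2 to compound 4 (0.14 log units; within the scatter) stays within it, as does a 1.7-fold higher number from compound 2 to compound 3 (0.24 log units; within the scatter), so only cyano and nitro separate among these three groups. On the side chain, 1-hydroxyethyl in place of methyl on a carbonyl carbon gives a 1.1-fold lower number from compound 1 to compound 4 (0.04 log units; within the scatter), which is within the scatter, so with nitro on the ring these two side chains cannot be told apart in this test. Nothing measured alongside these numbers accounts for the step from cyano to nitro.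

Still open, from the compounds shown here alone, is how an amine or a carboxylic acid on this aromatic carbon would read, and whether a longer chain on the carbonyl carbon would shift the number. Also open is whether the gap between cyano and nitro holds with methyl on the carbonyl carbon, since among these compounds only compound 1 carries that methyl.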